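The compounds below may be only part of what the source reports. "The series", "measured", "known", "first", "only" and "open" are said of these compounds alone.

Measured compounds:
compound 1 `N#C/N=C1\N(CCCCCOc2ccc(Cl)cc2)C(=O)CCN1c1ccncc1`: 3120 nM
compound 2 `N#C/N=C1\N(CCCCCCOc2ccc(Cl)cc2)C(=O)CCN1c1ccncc1`: 288 nM

In a functional assay on NUGC cells (stomach, Homo sapiens) for cytotoxicity (a higher number here means a weaker inhibitor, a lower number a stronger inhibitor), compound 2 gives the lower of the two numbers, and compound 1 gives 3120 nM. Among the compounds with values here, the only measured step, an 11-fold lower number from compound 1 to compound 2 (1.03 log units; beyond the scatter), is a single lengthening of the chain between the ring nitrogen and the aryl ether.

Compound 3 `N#C/N=C1\N(CCCCCCCOc2ccc(Cl)cc2)C(=O)CCN1c1ccncc1` is not yet measured. It differs from compound 2 by (4-chlorophenoxy)methyl in place of 4-chlorophenoxy on a saturated chain carbon, six bonds along the chain from an amide-type nitrogen in a ring. This is the same kind of change once more, one carbon further out. Within the data shown here, only one step bears on it, and that step was large; whether a further lengthening continues in the same direction, levels off, or turns back cannot be read from a single step. The expectation for this assay is therefore cautious: a step of a 1.2-fold lower number from compound 2 to compound 3 (0.06 log units; within the scatter), at most a modest lowering, possibly none beyond the scatter. Compound 3 is expected to give 250 nM, within a range of 70 nM to 900 nM.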

Compound 3, half-maximal inhibitory concentration: 1100 nM
The estimate for compound 3 lay 4.4-fold (0.64 log units) below the measured number; measured number above the stated range.
By their numbers in this assay, from the lowest: compound 2; then compound 3; then compound 1.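

In this assay the chain length at this position does not act in one direction: the added carbon now raises the number (a 3.8-fold higher number from compound 2 to compound 3 (0.58 log units; beyond the scatter)), whereas the earlier added carbon lowered it, so that among these three compounds the lowest number belongs to the middle chain, that of compound 2. The longest chain nevertheless keeps part of the earlier gain over the shortest (a 2.8-fold lower number from compound 1 to compound 3 (0.45 log units; beyond the scatter)), so the reversal does not return the number to where it started. No measurement shown here accounts for this turn in the number.

From the compounds shown here alone, whether a still longer chain would raise the number further or leave it level remains open. So does whether a chain ending in an amine or a carboxylic acid, in place of the 4-chlorophenoxy group, would show the same preference for the middle length.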